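This account rests on a few compounds, and the source may have more. Where it says the series, first, only, none or still open, it means among the compounds named here.

Of the compounds shown here, three of a shared core have been measured in a functional assay on HepG2 cells (Homo sapiens) for antiproliferative activity, read by CCK-8 assay, with a stated time of 72 h, tested at 8 uM; on this read-out higher numbers stand for a stronger effect at the one concentration tested and lower numbers for a weaker effect. Compound 1 `Nc1ccccc1NC(=O)/C=C/c1ccc(Cn2cnc3c(Nc4cccc(Cl)c4)nc(Cl)nc32)cc1` gives 49.3%, compound 2 `Nc1ccccc1NC(=O)/C=C/c1ccc(Cn2cnc3c(NC4CCCCC4)nc(Cl)nc32)cc1` gives 42.7%, and compound 3 `Nc1ccccc1NC(=O)/C=C/c1ccc(Cn2cnc3c(NCc4ccccc4)nc(Cl)nc32)cc1` gives 37.7%. Compound 3 stands lowest of the three: the change a number 11.6 percentage points lower from compound 1 to compound 3 (beyond the scatter) lies beyond the scatter, while a number 5 percentage points lower from compound 2 to compound 3 (within the scatter) and a number 6.6 percentage points lower from compound 1 to compound 2 (within the scatter) do not, so compound 3 and compound 2 cannot be set in order.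

Compound 4 `CC1CCN(c2nc(Cl)nc3c2ncn3Cc2ccc(/C=C/C(=O)Nc3ccccc3N)cc2)CC1` has not yet been measured. It differs from compound 3 in one place: 4-methylpiperidin-1-yl in place of benzylamino on an aromatic carbon. Within the data shown here, the step that bears on this is the one in which a saturated ring took the place of an aromatic one, a number 6.6 percentage points lower from compound 1 to compound 2 (within the scatter), and the one between compound 2 and compound 3, a number 5 percentage points lower from compound 2 to compound 3 (within the scatter), both within the scatter. Among the measured compounds shown here, the data give no step in which the nitrogen loses its hydrogen.

Compound 4 is therefore expected to give a value close to that of compound 3, a step of a number 2.3 percentage points higher from compound 3 to compound 4 (within the scatter), within the scatter. The estimate for compound 4 is 40%, expected to lie between 30% and 50%.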

Compound 4, a percentage reported as inhibition, at one concentration (the size of the read-out at that concentration, not a potency): 32.2%
Estimate against measurement, compound 4: 7.8 percentage points above, within the range that was stated.
By their numbers in this assay, from the lowest: compounds 4, 3, 2 and 1 (each within the scatter of the next, the first and the last beyond it).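

In this assay, among these compounds, compound 4 is the first of the series in which the group on this aromatic carbon has 0 hydrogen-bond donors, and the step of a number 5.5 percentage points lower from compound 3 to compound 4 (within the scatter) shows no readable change from benzylamino. Against the other two groups, however, the steps of a number 10.5 percentage points lower from compound 2 to compound 4 (beyond the scatter) and a number 17.1 percentage points lower from compound 1 to compound 4 (beyond the scatter) do pass the scatter, so 4-methylpiperidin-1-yl is the first group here to stand clearly below cyclohexylamino. Losing the hydrogen on that nitrogen does not remove the effect, since compound 4 still gives 32.2% at the one concentration tested.

Nothing at hand explains these steps. Going by these compounds, it remains open whether a plain piperidine, a morpholine or an open-chain dimethylamino group at this position would stay level with compound 4 or come closer to compound 1.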